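This account rests on a few compounds, and the source may have more. Where it says the series, first, only, none or still open, it means among the compounds named here.

Series notes. Compound 1 `COc1cccc(-c2c(S(=O)(=O)c3ccc(C)c(F)c3)cnc3c(F)cccc23)c1` and compound 2 `COc1cccc(S(=O)(=O)c2cnc3cc(F)ccc3c2-c2cccc(F)c2)c1` share a core. In an ADME assay on microsomes from liver (Homo sapiens) for metabolic stability, tested at 2.5 uM (on this read-out higher numbers stand for fast clearance and lower numbers for slow clearance), compound 1 gives 4.02 mL/min, and in this assay compound 2 gives 3.36 mL/min; the two numbers lie within the usual scatter of each other, so neither can be ranked against the other.

Compound 3 `O=S(=O)(c1cccc(F)c1)c1cnc2cc(F)ccc2c1-c1cccc(F)c1` differs from compound 2 by fluoro in place of methoxy on an aromatic carbon. Among the compounds with values here, no measured pair here carries that change, so its effect is unknown from these data; a small step downward in this assay is expected, plausibly no larger than the scatter. For compound 3 in this assay the estimate is 2.5 mL/min, in the range 1.2 mL/min to 5 mL/min, which means an expected step of a 1.3-fold lower number from compound 2 to compound 3 (0.13 log units; within the scatter).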

Compound 3, intrinsic clearance in a liver preparation (reported as CLH), per the amount of preparation that the assay uses: 0.24 mL/min
Estimate against measurement, compound 3: 10-fold (1.02 log units) above; the measured number lies below the stated range.
By their numbers in this assay, from the lowest: compound 3; then compounds 2 and 1 (each within the scatter of the next).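

In this assay, going from 3-methoxyphenyl to 3-fluorophenyl gives a 14-fold lower number from compound 2 to compound 3 (1.15 log units; beyond the scatter), so this one place on an aromatic carbon can carry a large change in the read-out. Compound 1 and compound 2 differ in more than one place and offered no such single-place comparison. Nothing at hand bears on the origin of this step.

As far as these compounds go, whether the step comes from losing methoxy or from gaining fluoro stays open, and a chloro, a nitrile or a plain hydrogen in the same place would separate the two. Whether the same swap carries over to the substitution pattern of compound 1 is also unsettled.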